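This account rests on a few compounds, and the source may have more. Where it says the series, first, only, none or still open, it means among the compounds named here.

Working notes on the series. Compound 1 `COC(=O)c1ccc(NCc2cncn2Cc2cccc(F)c2)cc1-c1ccccc1` and compound 2 `COC(=O)c1ccc(NCc2cncn2Cc2ccc(OC)cc2)cc1-c1ccccc1` share one core and differ only in a single aromatic substituent. In a toxicity assay on NIH3T3 cells (Mus musculus) for cytotoxicity, read by resazurin assay (a lower number here means that less compound is needed, a higher number that more compound is needed for the effect), compound 1 gives > 1000 nM, which is a limit of the assay and not a number. For the measured compounds named here, for compound 2 in this assay the record reads "not determined" (no result reported), so compound 2 has no single number to stand on; the only reading in the set is the limit of > 1000 nM in this assay, at which 1 of the 2 values shown sits. Compound 3 `COC(=O)c1ccc(NCc2cncn2Cc2ccc([N+](=O)[O-])cc2)cc1-c1ccccc1` is the next member and is still to be measured in this assay. Its difference from compound 2 is nitro in place of methoxy on an aromatic carbon. Going by the values given here, with no measured step between any two compounds, the size of the step in this assay cannot be taken from a precedent; the working expectation is no shift beyond the usual scatter, in either direction, and a reading that again sits at the limit rather than at a resolved number. Compound 3 is therefore expected at 2000 nM, with a range from 800 nM to 6000 nM, most likely reported only as a limit.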

Compound 3, half-maximal effective concentration: > 10000 nM
Compound 3 ended at the assay's limit; the forecaster's own chance of this, stated with the estimate: 80%; middle value at least 5.0-fold (0.69 log units) from the limit.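

In this assay compound 3 gives > 10000 nM, which is a limit and not a number. For the compounds shown here, compound 1 also stands at a limit, so no step between compound 1 and compound 3 can be read. The compounds shown leave open what resolved number, if any, either compound would give in this assay.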